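The source may report more compounds than this note shows. Statements on the series, on what has been measured and on what is new or still open speak of the compounds shown alone.

Of the compounds shown here, three built on one shared core have been tested in a functional assay on ileum for inhibition of histamine H1 receptor (Cavia porcellus); on this read-out lower numbers stand for stronger inhibition and higher numbers for weaker inhibition. Compound 1 `CCCOCCn1c(N2CCN(C)CC2)nc2ccccc21` gives 20 nM. Compound 2 `CCCn1c(N2CCN(C)CC2)nc2ccccc21` gives 380 nM. Compound 3 `CCCCCCn1c(N2CCN(C)CC2)nc2ccccc21` gives 26 nM. Among these three numbers compound 3 stands second highest: it sits close to compound 1, with a 1.3-fold higher number from compound 1 to compound 3 (0.11 log units; within the scatter), and far from compound 2, with a 15-fold lower number from compound 2 to compound 3 (1.16 log units; beyond the scatter) and a 19-fold higher number from compound 1 to compound 2 (1.28 log units; beyond the scatter) showing how much the short propyl chain loses against either longer chain.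

Compound 4 `CCSCCCn1c(N2CCN(C)CC2)nc2ccccc21` differs from compound 3 by ethylsulfanyl in place of propyl on a saturated chain carbon, three bonds along the chain from an aromatic nitrogen. For the measured compounds named here, the step that bears most directly on this is the one from compound 1 to compound 3, where an oxygen-containing chain and an all-carbon chain of the same heavy-atom count gave numbers within the scatter of each other. The chain of compound 4 again contains one heteroatom in place of one chain carbon, and it keeps the full chain length whose loss cost so much between compound 2 and compound 3. A step from compound 3 to compound 4 of no more than the scatter is therefore expected, if anything slightly downward. Compound 4 is expected to give 20 nM, in a range from 8 nM to 60 nM. This estimate means an expected 1.3-fold lower number from compound 3 to compound 4 (0.11 log units; within the scatter).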

Compound 4, half-maximal inhibitory concentration: 530 nM
The estimate for compound 4 lay 27-fold (1.42 log units) below the measured number; measured number outside the range, above it.
By their numbers in this assay, from the lowest: compounds 1 and 3 (each within the scatter of the next); then compounds 2 and 4 (each within the scatter of the next).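

In this assay, the count of heavy atoms alone does not settle the outcome at this position: ethylsulfanyl and propyl each hold 3 heavy atoms, yet the swap gives a 20-fold higher number from compound 3 to compound 4 (1.31 log units; beyond the scatter). A chain carrying a heteroatom is not enough to hold the low number either, since the 3-(ethylsulfanyl)propyl chain falls well short of the propoxy-bearing chain, with a 27-fold higher number from compound 1 to compound 4 (1.42 log units; beyond the scatter). Ethylsulfanyl in place of hydrogen on this carbon also brings no change beyond the scatter, with a 1.4-fold higher number from compound 2 to compound 4 (0.14 log units; within the scatter), whereas propyl in that same place gave a large improvement.

Nothing available explains why the sulfur-containing chain behaves so differently. Going by these compounds, it also remains open whether the identity of the heteroatom or its place in the chain matters more, since the propoxy group sits on a saturated chain carbon two bonds along the chain from an aromatic nitrogen and the ethylsulfanyl group sits three bonds along; a 3-ethoxypropyl chain, with oxygen where compound 4 has sulfur, would separate these two differences.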